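Maximal response in the series: cyclopentyl to tert-butyl

The source may report more compounds than this note shows. Statements on the series, on what has been measured and on what is new or still open speak of the compounds shown alone.

Measured so far:
compound 1, `Cc1c(OCCCCOc2ccc(C(=O)CC(C)(C)C)c(O)c2C)cccc1C(=O)O`, 109%
compound 2, `Cc1c(OCCCCOc2ccc(F)c(C(=O)O)c2)ccc(C(=O)CC2CCCC2)c1O`, 98.4%
compound 3, `Cc1c(OCCCCOc2ccccc2C(=O)O)ccc(C(=O)CC2CCCC2)c1O`, 32.9%

In an assay on HEK293 cells for positive allosteric modulation of metabotropic glutamate receptor 3 (Rattus norvegicus), read by thallium flux, with a stated time of 2.5 min (a lower number here means a smaller maximal response, a higher number a larger maximal response), compound 2 stands second highest of the three numbers; compound 1 lies higher by a margin beyond the scatter, and compound 3 lies far lower. Within the data shown here, the one step measured so far in this set, a number 65.5 percentage points lower from compound 2 to compound 3 (beyond the scatter), concerns the aryl group on the chain oxygen, not the alkyl on the ketone side.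

Compound 4, `Cc1c(OCCCCOc2ccc(F)c(C(=O)O)c2)ccc(C(=O)CC(C)(C)C)c1O`, keeps the aryl group of compound 2 and differs from it only at the ketone side: tert-butyl in place of cyclopentyl on a saturated chain carbon bound to a carbonyl carbon. Among the measured compounds shown here, no measured step isolates this change. Compound 1 also carries tert-butyl and gives a high response, but it differs from compound 2 in two places, so its value only shows that the tert-butyl series can reach the top of the present range. For the measured compounds named here, with no direct precedent, no step beyond the scatter is expected: compound 4 is estimated at 100%, range 78% to 118%, which means a step of a number 1.6 percentage points higher from compound 2 to compound 4 (within the scatter).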

Compound 4, largest response reached (reported as percent of maximum), in percent of the reference or control that the assay uses: 102%
Beside the measured number, compound 4's estimate is 2 percentage points below it; the range from low to high includes it.
By their numbers in this assay, from the lowest: compound 3; then compounds 2, 4 and 1 (each within the scatter of the next, the first and the last beyond it).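

In this assay, the change from cyclopentyl to tert-butyl on a saturated chain carbon bound to a carbonyl carbon now has a direct reading (a number 3.6 percentage points higher from compound 2 to compound 4 (within the scatter)): with 3-carboxy-4-fluorophenyl held, the two groups are not told apart. With tert-butyl held, 3-carboxy-4-fluorophenyl and 3-carboxy-2-methylphenyl on an oxygen on a saturated carbon are not told apart either (a number 7 percentage points lower from compound 1 to compound 4 (within the scatter)), whereas 2-carboxyphenyl with cyclopentyl gave a large fall (a number 65.5 percentage points lower from compound 2 to compound 3 (beyond the scatter)). No measurement at hand accounts for these results.

As far as these compounds go, whether 2-carboxyphenyl gives a low response with tert-butyl as well remains open. Also open, from the compounds shown here alone, is how the maximal response changes with a phenyl or a longer chain on the ketone side, or with a primary amide in place of the carboxylic acid.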